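Trading pyridin-2-yl for 4-fluorophenyl on a triple bond

This account rests on a few compounds, and the source may have more. Where it says the series, first, only, none or still open, it means among the compounds named here.

In a functional assay on PC-3 cells (Homo sapiens) for antiproliferative activity, read by WST assay, with a stated time of 72 h (on this read-out higher numbers stand for weaker inhibition of growth and lower numbers for stronger inhibition of growth), compound 1 `N=C(N)c1ccc(/N=N/Nc2cccc(C#Cc3ccccn3)c2)cc1` gives 10400 nM. Compound 3 `N=C(N)c1ccc(/N=N/Nc2ccccc2C#Cc2ccc(F)cc2)cc1` gives 7400 nM, a number within the usual scatter of compound 1. Compound 2 `C#Cc1ccc(N/N=N/c2ccc(C(=N)N)cc2)cc1` gives 22500 nM, a number higher than that of compound 1 by more than the scatter, which means weaker inhibition of growth. Compound 4 `N=C(N)c1ccc(/N=N/Nc2cccc(C#Cc3ccc(F)cc3)c2)cc1` is still unmeasured. It differs from compound 1 by one change on a triple-bonded carbon: 4-fluorophenyl in place of pyridin-2-yl on a triple-bonded carbon. Going by the values given here, no measured pair shows this change directly, but compound 3 also carries 4-fluorophenyl and gives 7400 nM. The expected step, a 1.3-fold lower number from compound 1 to compound 4 (0.11 log units; within the scatter), is small and stays within the scatter. For compound 4 the estimated value is 8000 nM, with an expected range from 3500 nM to 18000 nM.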

Compound 4, concentration for 50% growth inhibition: 5300 nM
Beside the measured number, compound 4's estimate is 1.5-fold (0.18 log units) above it; measured number inside the range.
By their numbers in this assay, from the lowest: compounds 4, 3 and 1 (each within the scatter of the next); then compound 2.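

Going by these compounds alone, the step of a 2.0-fold lower number from compound 1 to compound 4 (0.29 log units; within the scatter) is the first direct reading of this change, since compound 3 carries its 4-fluorophenyl on a different framework. It shows that, on this triple-bonded carbon, a ring of carbon only and a ring holding nitrogen cannot be told apart by this measurement. Nothing measured here points to a cause for this result.

Still open, as far as these compounds go, is what this assay would read for a plain phenyl or a ring carrying an amine on this carbon. From the compounds shown here alone, whether any group here can shift the number beyond the scatter also remains unknown.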